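The compounds below may be only part of what the source reports. "The series", "measured", "known", "first", "only" and "open" are said of these compounds alone.

The three compounds measured in an assay on HeLa cells with Bile acid receptor (Homo sapiens) as the target, read by a luciferase reporter, with a stated time of 24 h (on this read-out lower numbers stand for an effect already at smaller amounts and higher numbers for an effect only at larger amounts of compound), share one core and differ only in the substituent on the benzylic ring. Compound 1, `CC(C)(C)c1ccc(C(=O)NCc2ccc(OC(F)(F)F)cc2)cc1`, gives 160 nM. Compound 2, `CC(C)(C)c1ccc(C(=O)NCc2ccc(N)cc2Cl)cc1`, gives 46 nM. Compound 3, `CC(=O)c1ccc(CNC(=O)c2ccc(C(C)(C)C)cc2)cc1`, gives 100 nM, which places it second highest of the three numbers: its nearest neighbour is compound 1, a gap within the scatter, and the value of compound 2 lies beyond the scatter below it. Going by the values given here, the one step among the measured compounds that bears on the next change is a 1.6-fold lower number from compound 1 to compound 3 (0.20 log units; within the scatter), a swap of one substituent on the same aromatic carbon for another that left the number essentially where it was.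

Compound 4, `COc1ccc(CNC(=O)c2ccc(C(C)(C)C)cc2)cc1`, is formed from compound 3 by the following change: methoxy in place of acetyl on an aromatic carbon. The group enters on an aromatic carbon of a six-membered aromatic ring of carbon only, para to a large group. Among the compounds with values here, because the only comparable swap at this position, a 1.6-fold lower number from compound 1 to compound 3 (0.20 log units; within the scatter), stayed within the scatter, no step beyond the scatter is expected in this assay, in either direction. Compound 4 is therefore expected to show a step of a 1.5-fold higher number from compound 3 to compound 4 (0.18 log units; within the scatter). The estimated value of compound 4 is 150 nM, with a range from 60 nM to 400 nM.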

Compound 4, half-maximal effective concentration: 150 nM
Compound 4: middle estimate and measured number agree at the digits printed, and the stated range covers the measured number.
By their numbers in this assay, from the lowest: compound 2; then compounds 3, 4 and 1 (each within the scatter of the next).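

In this assay the exchange of acetyl for methoxy gives a 1.5-fold higher number from compound 3 to compound 4 (0.18 log units; within the scatter) and thus adds a second swap at this position that stays within the scatter, even though acetyl carries a double bond outside the aromatic ring and methoxy carries none. Going by these compounds alone, the new compound also gives the first comparison on the oxygen itself: methyl in place of trifluoromethyl gives a 1.1-fold lower number from compound 1 to compound 4 (0.03 log units; within the scatter) and likewise stays within the scatter, so that compound 1, compound 3 and compound 4 cannot be told apart on this read-out, despite the different groups they carry at this position. Nothing in the data shown accounts for this closeness.

Going by these compounds, whether a carboxylic acid, a longer alkoxy chain or an amine alone at this position would give a step beyond the scatter stays open. On these data alone, it is also open whether these same swaps would stay within the scatter on a core that carries another group in place of the tert-butyl.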